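Chloro for Fluoro on the Aryl Ring of Compound 3

The source may report more compounds than this note shows. Statements on the series, on what has been measured and on what is new or still open speak of the compounds shown alone.

Compound 3 `CN(C)C/C=C(\c1cccnc1)c1cccc(F)c1` gives the lowest number of the three measured compounds in a functional assay on brain for inhibition of Norepinephrine transporter (Rattus norvegicus) (a higher number here means a weaker inhibitor, a lower number a stronger inhibitor), at 2200 nM. Compound 1 `CN(C)C/C=C(/c1ccccc1)c1cccnc1` gives 27000 nM, and compound 2 `CCNC/C=C(/c1ccc(Br)cc1)c1cccnc1` gives 26000 nM. Putting fluoro in place of hydrogen on an aromatic carbon brought a 12-fold lower number from compound 1 to compound 3 (1.09 log units; beyond the scatter). Compound 4 `CN(C)C/C=C(\c1cccnc1)c1cccc(Cl)c1` differs from compound 3 by chloro in place of fluoro on an aromatic carbon. Among the compounds with values here, no measured step exchanges one halogen for another at this place; the only step that bears on it is a 12-fold lower number from compound 1 to compound 3 (1.09 log units; beyond the scatter), which shows that a halogen at this carbon is well tolerated. Compound 4 is therefore expected to shift by only a 1.5-fold lower number from compound 3 to compound 4 (0.17 log units; within the scatter) in this assay. Compound 4 is estimated at 1500 nM in this assay, probably between 500 nM and 5000 nM.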

Compound 4, half-maximal inhibitory concentration: 11000 nM
For compound 4 the middle estimate is 7.3-fold (0.87 log units) below the measured one; measured number above the stated range.
By their numbers in this assay, from the lowest: compound 3; then compound 4; then compounds 2 and 1 (each within the scatter of the next).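

In this assay, the identity of the halogen at this carbon matters, with a 5.0-fold higher number from compound 3 to compound 4 (0.70 log units; beyond the scatter), so fluoro and chloro are not interchangeable here. Chloro still keeps part of the gain seen with fluoro over hydrogen, with a 2.5-fold lower number from compound 1 to compound 4 (0.39 log units; beyond the scatter), giving the order fluoro, chloro, hydrogen among these three compounds. Nothing at hand explains the gap between the two halogens. The compounds shown leave open where a bromo or methoxy group at this carbon would fall. They also leave open whether this order holds on other positions of the same aromatic ring.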